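The source may hold more compounds than are shown below. What is called first, only, known or untested is meant among the compounds shown, and "the series" means these compounds.

Three related compounds have been tested in a functional assay on MDA-MB-231 cells (Homo sapiens) for antiproliferative activity, read by MTT assay, with a stated time of 48 h; on this read-out higher numbers stand for weaker inhibition and lower numbers for stronger inhibition. Compound 1 `CCOC(=O)CNc1nc(Nc2cccc(OC)c2)ncc1[N+](=O)[O-]` gives 31300 nM, the lowest of the three numbers. Compound 2 `COC(=O)CN(C)c1nc(NCc2ccccc2)ncc1[N+](=O)[O-]` gives 61100 nM, a number that sits within the usual scatter of compound 1, so the two cannot be ranked. Compound 3 `CCOC(=O)CN(Cc1ccccc1)c1nc(NCc2cccc(OC)c2)ncc1[N+](=O)[O-]` gives 80700 nM, and its gap from compound 1 lies beyond the scatter. Compound 4 `CCOC(=O)CNc1nc(Nc2ccc(Cl)cc2)ncc1[N+](=O)[O-]` has not yet been measured in this assay. It differs from compound 1 in one place: 4-chlorophenyl in place of 3-methoxyphenyl on a nitrogen on an aromatic ring. Going by the values given here, no measured pair shows this change, so there is no step to rest on. The expected step is a 1.0-fold higher number from compound 1 to compound 4 (0.01 log units; within the scatter), none beyond the scatter. Compound 4 is estimated at 32000 nM, with a range from 12000 nM to 85000 nM.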

Compound 4, half-maximal inhibitory concentration: 55500 nM
For compound 4 the middle estimate is 1.7-fold (0.24 log units) below the measured one; the range from low to high includes it.
By their numbers in this assay, from the lowest: compounds 1, 4, 2 and 3 (each within the scatter of the next, the first and the last beyond it).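

In this assay, 4-chlorophenyl in place of 3-methoxyphenyl on a nitrogen on an aromatic ring gives a 1.8-fold higher number from compound 1 to compound 4 (0.25 log units; within the scatter), so the two compounds cannot be ranked. Going by these compounds alone, this is the only measured step at this position, and it shows that exchanging these two substituted phenyl groups does not separate the numbers beyond the scatter. No measurement at hand bears on this result.

From the compounds shown here alone, it remains open whether a carboxylic acid, an amine or a longer chain on this nitrogen would move the number beyond the scatter.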